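Swapping the benzyl arm of an oxadiazole sulfonamide series

The source may hold more compounds than are shown below. What is called first, only, known or untested is meant among the compounds shown, and "the series" means these compounds.

Measured compounds:
compound 1, `COc1ccc(Cc2nnc(CN(c3cccc(Cl)c3Cl)S(=O)(=O)c3ccc(C)cc3)o2)cc1`, 39.8 nM
compound 2, `Cc1ccc(S(=O)(=O)N(Cc2nnc(Cc3ccc(N(C)C)cc3)o2)c2cccc(Cl)c2C)cc1`, 20 nM

In a functional assay on CHO cells for antagonist activity at prostaglandin E2 receptor EP1 subtype (Homo sapiens), read by FLIPR and calcium flux (on this read-out lower numbers stand for stronger inhibition and higher numbers for weaker inhibition), compound 2 gives 20 nM, and in this assay compound 1 gives 39.8 nM. The two numbers lie within the usual scatter of each other, so compound 2 cannot be set apart from compound 1 on these data; the two compounds also differ in more than one place, so nothing can be read about any single change from this pair.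

Compound 3, `Cc1ccc(S(=O)(=O)N(Cc2nnc(Cc3ccc(Cl)cc3Cl)o2)c2cccc(Cl)c2C)cc1`, is not yet measured. It differs from compound 2 in one place: 2,4-dichlorophenyl in place of 4-(dimethylamino)phenyl on a saturated chain carbon bound to an aromatic carbon. Among the measured compounds shown here, no measured pair shows this change, and nothing here separates the effect of the benzyl arm from that of the other ring. A step no larger than the scatter is expected in this assay, with no direction favoured. Compound 3 is estimated at 35 nM, between 10 nM and 125 nM, a step of a 1.8-fold higher number from compound 2 to compound 3 (0.24 log units; within the scatter) that is expected to stay within the scatter.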

Compound 3, inhibition constant: 1000 nM
Compound 3: middle estimate off by 29-fold (1.46 log units), on the low side; measured number above the stated range.
By their numbers in this assay, from the lowest: compounds 2 and 1 (each within the scatter of the next); then compound 3.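

In this assay, placing 2,4-dichlorophenyl in place of 4-(dimethylamino)phenyl on a saturated chain carbon bound to an aromatic carbon gives a 50-fold higher number from compound 2 to compound 3 (1.70 log units; beyond the scatter), so the group held at this position matters to inhibition. Compound 1 and compound 2 could not show this: they differ in more than one place, and their numbers lie within the scatter, whereas this single change has a clear effect, towards weaker inhibition. No measurement shown here speaks to what lies behind the step.

The compounds shown leave open whether the step follows from losing the dimethylamino group or from gaining the two chlorines, as this one change does both. An unsubstituted phenyl or a 4-chlorophenyl at the same place on the core of compound 2 would begin to separate the two.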